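A few compounds are considered here, and "the series" means these few. Any claim that something is new, unique, unknown or untested is made for them only; others in the source may bear on it.

Measured so far:
- compound 1, `O=C1c2c[n+]([O-])c3ccccc3c2C(=O)c2c1c1ccccc1n2Cc1cn([C@H]2O[C@H](CO)[C@@H](O)[C@H]2O)nn1`: 2680 nM
- compound 2, `O=C1c2c[n+]([O-])c3ccccc3c2C(=O)c2c1c1ccccc1n2Cc1cn(C[C@H](O)CO)nn1`: 1030 nM

Both were tested in a functional assay on A549 cells (Homo sapiens) for cytotoxicity, read by MTT assay, with a stated time of 72 h; a lower number here means a stronger inhibitor, a higher number a weaker inhibitor. Compound 2 gives the lowest number of the two; compound 1 sits at a higher number, and the step of a 2.6-fold lower number from compound 1 to compound 2 (0.42 log units; beyond the scatter) is beyond the scatter, so the open-chain diol on the triazole nitrogen goes with a stronger inhibitor than the sugar ring.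

Compound 3, `CC1(C)O[C@@H](CO)[C@H](Cn2cc(Cn3c4c(c5ccccc53)C(=O)c3c[n+]([O-])c5ccccc5c3C4=O)nn2)O1`, has not yet been measured in this assay. Its change from compound 2 is 5-(hydroxymethyl)-2,2-dimethyl-1,3-dioxolan-4-yl in place of 1,2-dihydroxyethyl on a saturated chain carbon bound to an aromatic nitrogen. Within the data shown here, the one measured step bears on it only loosely: it ran from a ring bearing several hydroxyls to an open chain, and the present change runs the other way, back to a ring and with fewer hydrogen-bond donors. A modest rise in the number is therefore expected for compound 3, a step of a 1.9-fold higher number from compound 2 to compound 3 (0.29 log units; within the scatter), landing near 2000 nM with a range from 900 nM to 4500 nM.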

Compound 3, half-maximal inhibitory concentration: 370 nM
Compound 3: middle estimate off by 5.4-fold (0.73 log units), on the high side; the whole stated range lies above it.
By their numbers in this assay, from the lowest: compound 3; then compound 2; then compound 1.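

In this assay, putting 5-(hydroxymethyl)-2,2-dimethyl-1,3-dioxolan-4-yl in place of 1,2-dihydroxyethyl gives a 2.8-fold lower number from compound 2 to compound 3 (0.44 log units; beyond the scatter) and shows that this position on the saturated chain carbon accepts a larger, ring-bearing group with one hydrogen-bond donor instead of two. The earlier pair alone might have suggested that a ring goes with a weaker inhibitor, but compound 3 goes against that reading, and only compound 1 still fits it: the comparison of the two ring-bearing groups gives a 7.2-fold lower number from compound 1 to compound 3 (0.86 log units; beyond the scatter) as the widest step in the set. No measurement shown here explains why the number falls.

The compounds shown cannot separate the effect of the two methyl groups from that of the closed ring. An amine or a carboxylic acid at this place, or a longer chain, would show how far the trend extends.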